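Replacing a 3-(nitrooxy)propyl group with hydrogen in compound 2

The source may hold more compounds than are shown below. What is called first, only, known or untested is meant among the compounds shown, and "the series" means these compounds.

Measured so far in a functional assay on M4E cells (Homo sapiens) for cytotoxicity, read by resazurin assay, with a stated time of 72 h; a higher number here means a weaker inhibitor, a lower number a stronger inhibitor 
compound 1 `O=C(/C=C/c1ccc(OCCCCO[N+](=O)[O-])c(O)c1)OCCCCO[N+](=O)[O-]` gives > 50000 nM (a limit)
compound 2 `COc1cc(/C=C/C(=O)OCCCO[N+](=O)[O-])ccc1OCCCO[N+](=O)[O-]` gives > 50000 nM (a limit)
compound 3 `O=C(/C=C/c1ccc(O)c(O)c1)OCc1c(-c2ccccc2)no[n+]1[O-]` gives 12900 nM (a number)

Compound 2 gives > 50000 nM in this assay and this is a limit of the assay, not a number. Compound 2 thus stands at the limit of > 50000 nM in this assay, at which 2 of the 3 values shown sit, and compound 1 shares that position. Within the data shown here, only compound 3 yields an actual number, and no two measured compounds differ in just one place, so no measured step is available as a guide.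

The next compound to be tested is compound 4 `COc1cc(/C=C/C(=O)OCCCO[N+](=O)[O-])ccc1O` which differs from compound 2 in one place (hydrogen in place of 3-(nitrooxy)propyl on an oxygen on an aromatic ring). In words, hydrogen stands in place of 3-(nitrooxy)propyl on an oxygen on an aromatic ring, and the same difference can be read as 3-(nitrooxy)propoxy to hydroxy.

The expected step in this assay is small, an at least 1.1-fold lower number from compound 2 to compound 4 (0.04 log units; that floor lies within the scatter) as an estimate, and no change beyond the scatter is foreseen. That expectation rests on compound 2 sitting at > 50000 nM with nothing measured to show what this change does. There is a real chance that the result will again be only a limit. For compound 4 the estimated value is 45000 nM with an expected range from 18000 nM to 100000 nM until the measurement is in.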

Compound 4, half-maximal inhibitory concentration: 18400 nM
Compound 4: middle estimate off by 2.4-fold (0.39 log units), on the high side, within the range that was stated.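

In this assay, among these compounds, the change from 3-(nitrooxy)propyl to hydrogen on an oxygen on an aromatic ring gives an at least 2.7-fold lower number from compound 2 to compound 4 (0.43 log units; beyond the scatter), the first measured step. Among the compounds shown here, this shows that the position matters in this assay: the earlier compounds offered no pair differing in one place, whereas here a single change moves the result beyond the usual scatter, and the 3-(nitrooxy)propyl group at this oxygen is not needed for compound 4 to give a measurable number. The true size of the step remains unknown because compound 2 has a limit and not a number: the limit of > 50000 nM in this assay, at which 2 of the 4 values shown sit.

The change removes the whole chain and also leaves a free hydroxy, so the compounds shown cannot tell whether losing the nitrooxy end or gaining the hydroxy accounts for the step. On these data alone, it also remains open whether a plain ethyl group or a propyl chain ending in an amine at this oxygen would behave more like hydrogen or more like 3-(nitrooxy)propyl.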